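This account rests on a few compounds, and the source may have more. Where it says the series, first, only, none or still open, it means among the compounds named here.

Working notes on the series. Within the data shown here, in a functional assay (strain AB) with Danio rerio as the target, read by microscopy, with a stated time of 1 h (on this read-out lower numbers stand for an effect already at smaller amounts and higher numbers for an effect only at larger amounts of compound), compound 3 `COCCCN1CCc2c(sc(NC(=O)Nc3ccc(Cl)cc3)c2C(N)=O)C1` gives 2400 nM, the smallest number of the three measured so far. Compound 1 `NC(=O)c1c(NC(=O)Nc2ccc(Cl)cc2)sc2c1CCN(C1CCOCC1)C2` gives 2830 nM, and the step of a 1.2-fold lower number from compound 1 to compound 3 (0.07 log units; within the scatter) keeps the pair together. Compound 2 `CC(C)(C)CN1CCc2c(sc(NC(=O)Nc3ccc(Cl)cc3)c2C(N)=O)C1` gives 5560 nM; here a 2.3-fold lower number from compound 2 to compound 3 (0.36 log units; beyond the scatter), whereas a 2.0-fold higher number from compound 1 to compound 2 (0.29 log units; within the scatter). Compound 4 `NC(=O)c1c(NC(=O)Nc2ccc(Cl)cc2)sc2c1CCN(CC1CCC1)C2` differs from compound 3 by cyclobutyl in place of 2-methoxyethyl on a saturated chain carbon bound to an amine nitrogen in a ring. The step that bears on this is a 2.3-fold lower number from compound 2 to compound 3 (0.36 log units; beyond the scatter), a change at the same place that likewise swapped a group with one hydrogen-bond acceptor for one of carbon only; read backwards it points to a modest rise. A step of about a 1.8-fold higher number from compound 3 to compound 4 (0.24 log units; within the scatter) toward a higher number is therefore expected. Compound 4 is estimated at 4200 nM, within 2000 nM to 9000 nM.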

Compound 4, half-maximal effective concentration: 1360 nM
The estimate for compound 4 lay 3.1-fold (0.49 log units) above the measured number, outside the stated range (below it).
By their numbers in this assay, from the lowest: compounds 4, 3, 1 and 2 (each within the scatter of the next, the first and the last beyond it).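

In this assay, a group of carbon only on a saturated chain carbon bound to an amine nitrogen in a ring does not by itself go with a higher number (a 1.8-fold lower number from compound 3 to compound 4 (0.25 log units; within the scatter)). The carbon-only groups themselves differ (a 4.1-fold lower number from compound 2 to compound 4 (0.61 log units; beyond the scatter)), so compound 2 and compound 4 stand against any reading based on the hydrogen-bond acceptor alone. Cyclobutylmethyl also separates from oxan-4-yl on an amine nitrogen in a ring (a 2.1-fold lower number from compound 1 to compound 4 (0.32 log units; beyond the scatter)). As far as these compounds go, whether cyclopropyl or cyclopentyl would follow cyclobutyl at this place remains open, as does the reading for a chain ending in an amine. No measurement at hand accounts for these steps.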